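Shrinking the Sulfonyl Substituent of an Inactive Sulfonamide

The source may hold more compounds than are shown below. What is called first, only, known or untested is meant among the compounds shown, and "the series" means these compounds.

Compound 1 `COc1ccc(Cl)cc1S(=O)(=O)Nc1ccc(-c2nc3ccccc3o2)cc1` was examined in an assay on isolated protein for inhibition of malate dehydrogenase, mitochondrial (Sus scrofa), with stated times of 45 min and 30 min; a lower number here means a stronger inhibitor, a higher number a weaker inhibitor. In this assay compound 1 gives > 63000 nM, which is a limit of the assay and not a number. Compound 2 `O=S(=O)(Nc1ccc2oc(-c3ccccc3)nc2c1)c1ccc(O)cc1` gives > 63000 nM in this assay, again only a limit. Both results sit at the same limit (the limit of > 63000 nM in this assay, at which 2 of the 2 values shown sit). Compound 3 `CS(=O)(=O)Nc1ccc(-c2nc3ccccc3o2)cc1` differs from compound 1 by methyl in place of 5-chloro-2-methoxyphenyl on a sulfonyl sulfur. Within the data shown here, no measured step between two compounds exists to guide the size of this change. Since compound 1 gives only a limit > 63000 nM, the expected step is a step that the limit leaves unreadable from compound 1 to compound 3, nothing beyond the scatter. Compound 3 is expected to give about 100000 nM in this assay, between 40000 nM and 300000 nM, most likely again only a limit.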

Compound 3, half-maximal inhibitory concentration: > 63000 nM
Compound 3 gave a limit, no number; the forecaster's own chance of this, stated with the estimate: 85%; the middle value is on the limit's open side.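

Among these compounds, compound 3, like compound 1, gives only a limit of the assay, so no step between these two compounds can be read: the limit of > 63000 nM in this assay, at which 3 of the 3 values shown sit. In this assay the compounds shown leave open what substituent on the sulfonyl sulfur, if any, would give a measurable value.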